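This account rests on a few compounds, and the source may have more. Where it says the series, first, only, none or still open, it means among the compounds named here.

Compound 1 `CCn1c(=O)n(C2OC(CO)[C@@H](O)[C@H]2O)c2nc(N)nc(O)c21` gives 82% in a functional assay on the whole organism (B cells) with Mus musculus as the target; a lower number here means a smaller maximal response, a higher number a larger maximal response. Compound 2 `C=CCn1c(=O)n(C2OC(CO[Si](c3ccccc3)(c3ccccc3)C(C)(C)C)[C@@H](O)[C@H]2O)c2nc(N)nc(O)c21` gives 33%. Compound 3 `Nc1nc(O)c2c(n1)n(C1OC(CO)[C@@H](O)[C@H]1O)c(=O)n2CC(O)CN1CCN(c2ccc(F)cc2)CC1` gives 16%.

Of these three, compound 1 stands highest; compound 2 lies below it by a gap beyond the usual scatter, and compound 3 lies further below, also beyond the scatter. Compound 4 `NC(=O)Cn1c(=O)n(C2OC(CO)[C@@H](O)[C@H]2O)c2nc(N)nc(O)c21` has not yet been measured. It differs from compound 1 in one place: carbamoyl in place of methyl on a saturated chain carbon bound to an aromatic nitrogen. For the measured compounds named here, no measured pair shows this exact change, so the expectation rests on the other two compounds, which carry other groups at that place but also differ elsewhere and both reach lower responses. A downward step of moderate size, a number 27 percentage points lower from compound 1 to compound 4 (beyond the scatter), is expected. Compound 4 is therefore estimated to reach about 55%, within a range from 25% to 85%.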

Compound 4, largest response reached (reported as maximal response), in percent of the reference or control that the assay uses: 32%
Compound 4: the middle estimate sits 23 percentage points above what was measured; the measured number falls inside the stated range.
By their numbers in this assay, from the lowest: compound 3; then compounds 4 and 2 (each within the scatter of the next); then compound 1.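

In this assay, putting carbamoyl in place of methyl on a saturated chain carbon bound to an aromatic nitrogen gives a large fall, a number 50 percentage points lower from compound 1 to compound 4 (beyond the scatter), with the rest of the molecule unchanged. For the compounds shown here, this is the first one-place comparison at this position, and it shows that the response depends on the group carried there, even when the change involves only 3 heavy atoms. The data shown offer no measured explanation for this fall.

As far as these compounds go, it remains open how a carboxylic acid, an amine or a longer chain ending in carbamoyl would behave at this place.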